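A few compounds are considered here, and "the series" means these few. Any claim that something is new, unique, unknown or untested is made for them only; others in the source may bear on it.

In an assay on HEK293 cells for inhibition of transient receptor potential cation channel subfamily V member 1 (Homo sapiens), read by FLIPR, at pH 5.5 (a higher number here means a weaker inhibitor, a lower number a stronger inhibitor), compound 1 `Cc1ccc(N2CCN(C(=O)Nc3ccc(C(C)C)cc3)CC2)nn1` gives only a limit, > 10000 nM. Compound 2 `Cc1ccc(N2CCN(C(=O)Nc3ccc(C(F)(F)F)cc3)CC2)nn1` likewise gives only a limit, > 10000 nM. The step that the two limits leave unreadable from compound 1 to compound 2 therefore cannot be sized, and the limit of > 10000 nM in this assay, at which 2 of the 2 values shown sit, is all that the measurements of this core offer. Compound 3 `Cc1cnnc(N2CCN(C(=O)Nc3ccc(C(C)C)cc3)CC2)c1` differs from compound 1 by 5-methylpyridazin-3-yl in place of 6-methylpyridazin-3-yl on an amine nitrogen in a ring. Among the compounds with values here, no measured step bears on a rearrangement of this kind. Compound 3 is accordingly expected to sit around 15000 nM, between 5000 nM and 50000 nM, with a limit again the likeliest outcome. The expected step is a step that the limit leaves unreadable from compound 1 to compound 3, no movement beyond the scatter.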

Compound 3, half-maximal inhibitory concentration: 20300 nM
The estimate for compound 3 lay 1.4-fold (0.13 log units) below the measured number; low and high end bracket the measured number.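

No step can be read from compound 1 to compound 3: compound 3 gives a number, but compound 1 gives only a limit. The compounds shown leave open whether 5-methylpyridazin-3-yl in place of 6-methylpyridazin-3-yl changes inhibition in this assay at all.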